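The source may report more compounds than this note shows. Statements on the series, on what has been measured and on what is new or still open speak of the compounds shown alone.

Measured in a functional assay for antagonist activity at transient receptor potential cation channel subfamily V member 1 (Homo sapiens), read by calcium flux; a higher number here means a weaker inhibitor, a lower number a stronger inhibitor:
Compound 1 `O=C(NCc1ccc(N2CCCCC2)cc1)Nc1cccc2cnccc12` gives 7.3 nM.
Compound 2 `O=C(NCc1ccc(N2CCCCCCC2)cc1)Nc1cccc2cnccc12` gives 4.7 nM.
Compound 3 `CC1CCN(c2ccc(CNC(=O)Nc3cccc4cnccc34)cc2)CC1` gives 9.3 nM.

Compound 3 carries the highest of the three numbers, yet its gaps to the others, a 1.3-fold higher number from compound 1 to compound 3 (0.11 log units; within the scatter) and a 2.0-fold higher number from compound 2 to compound 3 (0.30 log units; within the scatter), sit within the scatter; the three compounds are not separable in this assay.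

Compound 4 `CC1CN(c2ccc(CNC(=O)Nc3cccc4cnccc34)cc2)CC(C)O1` is not yet measured. It differs from compound 3 by 2,6-dimethylmorpholin-4-yl in place of 4-methylpiperidin-1-yl on an aromatic carbon. The steps that concern the same ring on the aromatic carbon are a 1.6-fold lower number from compound 1 to compound 2 (0.19 log units; within the scatter), a change of ring size, and a 1.3-fold higher number from compound 1 to compound 3 (0.11 log units; within the scatter), a methyl added on a saturated ring carbon, together with a 2.0-fold higher number from compound 2 to compound 3 (0.30 log units; within the scatter). All three stay within the scatter. Within the data shown here, none of them brings a second hetero atom into that ring, so this part of the change has no measured counterpart. The expectation is a step not clearly beyond the scatter, leaning if anything toward a higher number: a 1.6-fold higher number from compound 3 to compound 4 (0.21 log units; within the scatter). Compound 4 is estimated at 15 nM in this assay, with a range from 5 nM to 45 nM.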

Compound 4, half-maximal inhibitory concentration: 258 nM
Beside the measured number, compound 4's estimate is 17-fold (1.24 log units) below it; measured number outside the range, above it.
By their numbers in this assay, from the lowest: compounds 2, 1 and 3 (each within the scatter of the next); then compound 4.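

In this assay, this position, on an aromatic carbon para to a large group, had so far shown only steps within the scatter, but the change to 2,6-dimethylmorpholin-4-yl gives a 28-fold higher number from compound 3 to compound 4 (1.44 log units; beyond the scatter), along with a 35-fold higher number from compound 1 to compound 4 (1.55 log units; beyond the scatter) and a 55-fold higher number from compound 2 to compound 4 (1.74 log units; beyond the scatter). Heavy-atom count alone does not track this result: the eight-membered ring of compound 2 has the same count as the 2,6-dimethylmorpholin-4-yl group of compound 4, yet the two compounds lie far apart, so the position is sensitive to more than the group's size. No available evidence bears on the reason for the large step.

As far as these compounds go, the ring oxygen and the added methyl enter together in compound 4, so their separate shares of the step remain open. Morpholin-4-yl and 2,6-dimethylpiperidin-1-yl would separate those shares, while piperazin-1-yl would test a ring nitrogen in the same place.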